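Swapping tert-butyl for phenyl on the hydroxy-bearing carbon

A few compounds are considered here, and "the series" means these few. Any claim that something is new, unique, unknown or untested is made for them only; others in the source may bear on it.

Compound 1 `CC(C)(C)[C@@H](O)C(=O)N1OCC[C@H]1C(=O)NCc1cc(Cl)ccc1-n1cnnn1` gives < 12 mL.min-1.g-1 in an ADME assay on liver for metabolic stability, with Liver microsome (Homo sapiens) as the target, read by LC-MS, using microsomes (on this read-out higher numbers stand for fast clearance and lower numbers for slow clearance), and that value is a limit of the assay.
Compound 2 `CC(C)(C)C[C@@H](O)C(=O)N1N=CC[C@H]1C(=O)NCc1cc(Cl)ccc1-n1cnnn1` gives 22 mL.min-1.g-1 in this assay.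
Compound 3 `O=C(NCc1cc(Cl)ccc1-n1cnnn1)[C@@H]1CC=NN1C(=O)[C@H](O)Cc1ccccc1` gives < 12 mL.min-1.g-1 in this assay, which is again a limit of the assay.

Compound 2 and compound 3 share one core and differ in a single place: phenyl in place of tert-butyl on a saturated chain carbon, two bonds along the chain from a carbonyl carbon and an oxygen on a saturated carbon. In this assay this change gave an at least 1.8-fold lower number from compound 2 to compound 3 (0.26 log units; that floor lies within the scatter), so the two values cannot be told apart with confidence. Two of the three measured values, those of compound 1 and compound 3, sit at the limit of < 12 mL.min-1.g-1 in this assay, at which 2 of the 3 values shown sit.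

Compound 1 rests on a different core from compound 2; how the two cores differ is not broken down here. Compound 4 `O=C(NCc1cc(Cl)ccc1-n1cnnn1)[C@@H]1CCON1C(=O)[C@H](O)c1ccccc1` has not yet been measured. It is made from compound 1 by the same kind of change as that from compound 2 to compound 3: phenyl in place of tert-butyl on a saturated chain carbon bound to a carbonyl carbon and an oxygen on a saturated carbon. The surroundings are not identical, though. In compound 4 the phenyl enters on a saturated chain carbon bound to a carbonyl carbon and an oxygen on a saturated carbon, whereas in compound 3 it enters on a saturated chain carbon two bonds along the chain from those two atoms.

From compound 1 to compound 4 a step that the limit leaves unreadable from compound 1 to compound 4 is expected in this assay, resting on the measured step from compound 2 to compound 3 being an at least 1.8-fold lower number from compound 2 to compound 3 (0.26 log units; that floor lies within the scatter) and on compound 1 already sitting at a limit. Compound 4 is therefore estimated at 10 mL.min-1.g-1, most likely between 4 mL.min-1.g-1 and 22 mL.min-1.g-1, with a fair chance that only a limit is reported.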

Compound 4, intrinsic clearance in microsomes: < 12 mL.min-1.g-1
Compound 4: only a limit was reported; the forecaster's own chance of this, stated with the estimate: 60%; the middle value does not contradict the limit.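

In this assay compound 4 gives < 12 mL.min-1.g-1, which is a limit of the assay. Compound 1 and compound 4 therefore allow no readable step, because both values stand at the same limit: the limit of < 12 mL.min-1.g-1 in this assay, at which 3 of the 4 values shown sit.

The compounds shown leave open whether phenyl in place of tert-butyl changes intrinsic clearance on the core of compound 1 at all, and in which direction.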